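Working notes: amine replacement on the shared core

This account rests on a few compounds, and the source may have more. Where it says the series, first, only, none or still open, it means among the compounds named here.

Three compounds of the shared core have numbers in a functional assay on CHO-K1 cells for antagonist activity at transient receptor potential cation channel subfamily V member 1 (Homo sapiens), read by FLIPR; a lower number here means a stronger inhibitor, a higher number a weaker inhibitor. Compound 1 `CC(C(=O)NCc1ccc(C(F)(F)F)nc1NCC1CCN(C(=O)OC(C)(C)C)CC1)c1ccc(NS(C)(=O)=O)c(F)c1` gives 19.3 nM. Compound 2 `CCCCN(C)c1nc(C(F)(F)F)ccc1CNC(=O)C(C)c1ccc(NS(C)(=O)=O)c(F)c1` gives 0.8 nM, the second highest of the three; compound 3 `C[C@H](C(=O)NCc1ccc(C(F)(F)F)nc1N1CCC(c2ccccc2)CC1)c1ccc(NS(C)(=O)=O)c(F)c1` at 0.3 nM sits a step beyond the scatter below it, and compound 1 lies far above. Compound 4 `CC(=O)OC1CCN(c2nc(C(F)(F)F)ccc2CNC(=O)C(C)c2ccc(NS(C)(=O)=O)c(F)c2)CC1` is not yet measured; it differs from compound 2 in one place: 4-acetoxypiperidin-1-yl in place of butyl(methyl)amino on an aromatic carbon. Within the data shown here, no pair of measured compounds isolates this change. Because compound 3 reaches 0.3 nM with a piperidin-1-yl group on the same aromatic carbon, a ring there is tolerated. Compound 1 at 19.3 nM carries the other oxygen-bearing group. A modest step up in this assay is expected for compound 4, a 3.8-fold higher number from compound 2 to compound 4 (0.57 log units; beyond the scatter). The estimate for compound 4 is 3 nM, range 0.8 nM to 12 nM.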

Compound 4, inhibition constant: 4 nM
For compound 4 the middle estimate is 1.3-fold (0.12 log units) below the measured one; low and high end bracket the measured number.
By their numbers in this assay, from the lowest: compound 3; then compound 2; then compound 4; then compound 1.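

Among these compounds, the first direct pair at this position, compound 2 and compound 4, gives in this assay a 5.0-fold higher number from compound 2 to compound 4 (0.70 log units; beyond the scatter), for 4-acetoxypiperidin-1-yl in place of butyl(methyl)amino on an aromatic carbon. The position therefore accepts this larger ring-bearing group with a modest rise in the number, not a collapse of activity. Nothing measured here bears on the cause of this step.

The compounds shown do not separate the contribution of the six-membered ring from that of the acetoxy group. A 4-hydroxypiperidin-1-yl or an unsubstituted piperidin-1-yl group on this carbon would divide the step between them.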